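Adding dimethyl to the hydroxypiperidine amide of compound 3

A few compounds are considered here, and "the series" means these few. Any claim that something is new, unique, unknown or untested is made for them only; others in the source may bear on it.

In an ADME assay on cells (Hepatocyte, Rattus norvegicus, strain Wistar) for pharmacokinetics, read by LC-MS, with a stated time of 90 min, tested at 1 uM (on this read-out lower numbers stand for slow clearance and higher numbers for fast clearance), compound 1 `CCCN(CC1CCOC1)C(=O)c1cc(OC)c2oc(NCc3cccc(Cl)c3)nc2c1` gives 65 mL/min/kg and compound 2 `COc1cc(C(=O)N2CCCC2(C)C)cc2nc(NCc3cccc(Cl)c3)oc12` gives 58.3 mL/min/kg, a pair separated by a 1.1-fold lower number from compound 1 to compound 2 (0.05 log units; within the scatter). Compound 3 `COc1cc(C(=O)N2CCC(O)CC2)cc2nc(NCc3cccc(Cl)c3)oc12` has the lowest number of the three, at 21.7 mL/min/kg. The steps reaching it are modest: a 3.0-fold lower number from compound 1 to compound 3 (0.48 log units; beyond the scatter) and a 2.7-fold lower number from compound 2 to compound 3 (0.43 log units; beyond the scatter). Compound 4 `COc1cc(C(=O)N2CC[C@@H](O)C(C)(C)C2)cc2nc(NCc3cccc(Cl)c3)oc12` carries 4-hydroxy-3,3-dimethylpiperidin-1-yl in place of 4-hydroxypiperidin-1-yl on a carbonyl carbon. For the measured compounds named here, no measured step isolates this change, so those modest steps only loosely frame it. A small rise is expected, no larger than the scatter, as a 1.2-fold higher number from compound 3 to compound 4 (0.09 log units; within the scatter). For compound 4 the estimated clearance is 27 mL/min/kg, with an expected range of 14 mL/min/kg to 48 mL/min/kg.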

Compound 4, clearance: 51.7 mL/min/kg
The estimate for compound 4 lay 1.9-fold (0.28 log units) below the measured number; the measured number lies above the stated range.
By their numbers in this assay, from the lowest: compound 3; then compounds 4, 2 and 1 (each within the scatter of the next).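

In this assay, the added dimethyl is not a neutral change: a 2.4-fold higher number from compound 3 to compound 4 (0.38 log units; beyond the scatter), so keeping the hydroxyl on the piperidine ring does not by itself preserve the low number of compound 3. That step removes the separation seen earlier, with a 1.1-fold lower number from compound 2 to compound 4 (0.05 log units; within the scatter) and a 1.3-fold lower number from compound 1 to compound 4 (0.10 log units; within the scatter), leaving compound 4 indistinguishable from either amide without a hydroxyl. Nothing available explains the rise.

Going by these compounds, whether a single methyl on the ring, or a 4-aminopiperidin-1-yl amide, would keep the number of compound 3 remains open. So does the part played by the defined stereocentre of compound 4.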